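Swapping isopropyl for phenyl on compound 2

A few compounds are considered here, and "the series" means these few. Any claim that something is new, unique, unknown or untested is made for them only; others in the source may bear on it.

In an ADME assay on L929 cells (Mus musculus) for cytotoxicity, read by resazurin assay, with a stated time of 96 h (a higher number here means that more compound is tolerated, a lower number that less compound is tolerated), compound 1 (`NC(=S)N/N=C(/COc1ccc(Br)cc1)c1ccc(Cl)cc1`) gives 25100 nM and compound 2 (`CC(C)c1ccc(OC/C(=N\NC(N)=S)c2ccc(Br)cc2)cc1`) gives 24600 nM as its value. These two numbers lie within the usual scatter of each other, so the data do not separate the compounds. Compound 3 (`NC(=S)N/N=C(\COc1ccc(-c2ccccc2)cc1)c1ccc(Br)cc1`) has not yet been measured. It differs from compound 2 in one place: phenyl in place of isopropyl on an aromatic carbon, para to a large group (phenyl in place of isopropyl on an aromatic carbon). Within the data shown here, no measured pair shows what this swap does in this assay, so the expectation has little to lean on beyond the close agreement of the two known values. A step beyond the scatter is not expected. The estimated change a 1.2-fold lower number from compound 2 to compound 3 (0.09 log units; within the scatter) is small, leaning slightly towards less compound being tolerated. For compound 3 the estimated half-maximal cytotoxic concentration is 20000 nM with an expected range from 8000 nM to 50000 nM in repeat measurements.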

Compound 3, half-maximal cytotoxic concentration: 90800 nM
For compound 3 the middle estimate is 4.5-fold (0.66 log units) below the measured one; the measured number lies above the stated range.
By their numbers in this assay, from the lowest: compounds 2 and 1 (each within the scatter of the next); then compound 3.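

In this assay the aromatic carbon para to a large group turns out not to be a silent position: phenyl in place of isopropyl there gives a 3.7-fold higher number from compound 2 to compound 3 (0.57 log units; beyond the scatter) and so moves the result towards more compound being tolerated. Among these compounds, this is the only measured step at this position, and it shows that a single change here can carry the number beyond the usual scatter, which the two earlier compounds could not show. No measurement at hand explains why the number moves in this direction.

As far as these compounds go, with one step, it stays open whether the aromatic ring of phenyl matters or simply the larger count of heavy atoms. A longer chain of carbon atoms, an amine or a carboxylic acid at this same position could help to separate those two readings.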